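Swapping the aryl group at the ortho position: indole next

This account rests on a few compounds, and the source may have more. Where it says the series, first, only, none or still open, it means among the compounds named here.

Compound 1, `Nc1ccc(S(=O)(=O)N2CCN(c3ncc(C(O)(C(F)(F)F)C(F)(F)F)cc3C#CC3CC3)CC2)cn1`, compound 2, `Nc1ccc(S(=O)(=O)N2CCN(c3ncc(C(O)(C(F)(F)F)C(F)(F)F)cc3-c3ccccc3O)CC2)cn1`, compound 3, `CS(=O)(=O)c1ccc(-c2cc(C(O)(C(F)(F)F)C(F)(F)F)cnc2N2CCN(S(=O)(=O)c3ccc(N)nc3)CC2)cc1`.

In an ADME assay (liver) for metabolic stability, with Liver microsome (Homo sapiens) as the target, using microsomes and NADPH, with a stated time of 30 min, tested at 1 uM (a higher number here means faster removal of the compound, a lower number slower removal), compound 1 gives only a limit, < 14 mL.min-1.g-1. Compound 2 gives 22 mL.min-1.g-1. Compound 3 gives 32 mL.min-1.g-1, the larger of the two numbers, though a 1.5-fold higher number from compound 2 to compound 3 (0.16 log units; within the scatter), so the two cannot be told apart. Within the data shown here, the one step that stands clear is an at least 2.2-fold higher number from compound 1 to compound 3 (0.35 log units; beyond the scatter), and an at least 1.5-fold higher number from compound 1 to compound 2 (0.19 log units; that floor lies within the scatter).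

Compound 4, `Nc1ccc(S(=O)(=O)N2CCN(c3ncc(C(O)(C(F)(F)F)C(F)(F)F)cc3-c3cc4ccccc4[nH]3)CC2)cn1`, differs from compound 3 in one place: 1H-indol-2-yl in place of 4-(methylsulfonyl)phenyl on an aromatic carbon. Both steps that bear on this position, from compound 1 to compound 2 and to compound 3, ran toward faster removal once an aromatic ring replaced the alkyne, while the exchange of one aromatic ring for another between compound 2 and compound 3 stayed within the scatter. A further exchange of one aromatic ring for another is therefore expected to give a 1.1-fold higher number from compound 3 to compound 4 (0.04 log units; within the scatter), nothing beyond the scatter. Compound 4 is estimated at 35 mL.min-1.g-1, between 15 mL.min-1.g-1 and 80 mL.min-1.g-1.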

Compound 4, intrinsic clearance in microsomes: < 14 mL.min-1.g-1
Compound 4: a limit, no number; the forecaster's own chance of this, stated with the estimate: 5%; middle value at least 2.5-fold (0.39 log units) away from the limit.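

In this assay, an aromatic ring at this position does not by itself go with faster removal: 1H-indol-2-yl in place of 4-(methylsulfonyl)phenyl gives an at least 2.2-fold lower number from compound 3 to compound 4 (0.35 log units; beyond the scatter), whereas the earlier exchange of aromatic rings gave a 1.5-fold higher number from compound 2 to compound 3 (0.16 log units; within the scatter). With 1H-indol-2-yl in place of 2-hydroxyphenyl, the reading is an at least 1.5-fold lower number from compound 2 to compound 4 (0.19 log units; that floor lies within the scatter), so that step alone does not separate the two groups. The step between compound 1 and compound 4 cannot be read, and the true size of the other two steps stays hidden, as both compounds sit at the same reporting limit: the limit of < 14 mL.min-1.g-1 in this assay, at which 2 of the 4 values shown sit.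

On these data alone, what a benzofuran-2-yl or a 1-methyl-1H-indol-2-yl group would give at this place stays open. So does whether the hydrogen on the indole nitrogen has any part in the lower number of compound 4.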